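The compounds below may be only part of what the source reports. "The series", "measured", "known", "first", "only" and "open" are said of these compounds alone.

Two compounds built on the same core have so far been examined in an ADME assay on Vero cells (Chlorocebus sabaeus) for cytotoxicity, read by MTT assay, with a stated time of 72 h; a higher number here means a weaker inhibitor, a lower number a stronger inhibitor. Compound 1 `COc1ccccc1C1CC(c2cc3ccccc3o2)=NN1C(=O)c1ccncc1` carries a methoxy group on one aromatic ring. In this assay compound 1 gives > 202000 nM, which is a limit of the assay and not a number. Compound 2 `O=C(c1ccncc1)N1N=C(c2cc3ccccc3o2)CC1c1ccccc1Cl` carries a chloro group at the same place. In this assay compound 2 gives > 210000 nM, again a limit and not a number. The step that the two limits leave unreadable from compound 1 to compound 2 therefore cannot be read in size or direction, because the limit of > 202000 nM in this assay, at which 1 of the 2 values shown sits, and the limit of > 210000 nM in this assay, at which 1 of the 2 values shown sits, are where the two values sit. Within the data shown here, compound 2 thus stands only at a limit, and the one further value shown beside it is also a limit.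

Compound 3 `O=C(c1ccncc1)N1N=C(c2cc3ccccc3o2)CC1c1ccccc1` is the next member. Its difference from compound 2 is hydrogen in place of chloro on an aromatic carbon. Among the measured compounds shown here, the only measured step that bears on this change is the unreadable one from compound 1 to compound 2, so no size or direction can be taken from it. Compound 3 is expected to remain at the limit, so that the expected step that the limit leaves unreadable from compound 2 to compound 3 is none beyond the scatter. For compound 3 the estimated value in this assay is 250000 nM, within a range from 100000 nM to 600000 nM.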

Compound 3, half-maximal inhibitory concentration: > 209000 nM
Compound 3 gave a limit, no number (the forecaster's own chance of this, stated with the estimate: 85%); the middle value lies beyond the limit too.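

In this assay compound 3 gives > 209000 nM, a limit of the assay and not a number. Among these compounds, no step among compound 1, compound 2 and compound 3 can be read, in size or in direction. The compounds shown leave open how methoxy, chloro and hydrogen at this place compare in this assay.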